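Benzyl ether series: cytotoxicity and the cyano-to-methyl step

The source may report more compounds than this note shows. Statements on the series, on what has been measured and on what is new or still open speak of the compounds shown alone.

Measured so far:
compound 1 `O=c1c(OCc2ccccc2Cl)c(-c2ccccc2)oc2cc(O)cc(O)c12`: > 100000 nM (a limit of the assay, not a number)
compound 2 `O=c1c(OCc2cccc(Br)c2)c(-c2ccccc2)oc2cc(O)cc(O)c12`: 15000 nM
compound 3 `N#Cc1cccc(COc2c(-c3ccccc3)oc3cc(O)cc(O)c3c2=O)c1`: 21000 nM

In an ADME assay on Huh-5-2 cells (Homo sapiens) for cytotoxicity, read by WST assay, with a stated time of 3 days (a lower number here means that less compound is tolerated, a higher number that more compound is tolerated), compound 3 gives 21000 nM, the higher of the two numbers measured, but a 1.4-fold higher number from compound 2 to compound 3 (0.15 log units; within the scatter), so compound 2 and compound 3 are not separable. Compound 1 gives only a limit in this assay (the limit of > 100000 nM in this assay, at which 1 of the 3 values shown sits).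

Compound 4 `Cc1cccc(COc2c(-c3ccccc3)oc3cc(O)cc(O)c3c2=O)c1` differs from compound 3 by methyl in place of cyano on an aromatic carbon. Among the measured compounds shown here, no measured step exchanges cyano for methyl. For the measured compounds named here, the only step at the same position is a 1.4-fold higher number from compound 2 to compound 3 (0.15 log units; within the scatter), and that exchange of one group on this aromatic carbon for another stayed within the scatter. On that basis compound 4 is expected to show no step beyond the scatter, a 1.1-fold lower number from compound 3 to compound 4 (0.02 log units; within the scatter). The estimate for compound 4 in this assay is 20000 nM, with an expected range from 8000 nM to 60000 nM.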

Compound 4, half-maximal cytotoxic concentration: 29000 nM
For compound 4 the middle estimate is 1.5-fold (0.16 log units) below the measured one, within the range that was stated.
By their numbers in this assay, from the lowest: compounds 2, 3 and 4 (each within the scatter of the next). At a limit, above all of these: compound 1.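

At this aromatic carbon, methyl now stands with cyano and bromo without separation: a 1.4-fold higher number from compound 3 to compound 4 (0.14 log units; within the scatter), and a 1.9-fold higher number from compound 2 to compound 4 (0.29 log units; within the scatter). Exchanging cyano, with its hydrogen-bond acceptor, for methyl, with none, therefore gives no step beyond the scatter in this assay. The only step beyond the scatter still involves 2-chlorophenyl, an at least 3.4-fold lower number from compound 1 to compound 4 (0.53 log units; beyond the scatter), and it rests on a limit, not a number: the limit of > 100000 nM in this assay, at which 1 of the 4 values shown sits.

Still open, from the compounds shown here alone, is whether an amine or a carboxylic acid on this aromatic carbon would give a step beyond the scatter. Going by these compounds, the true size of the gap to compound 1 also remains open.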